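Branching of the alkyl group on the cyanoguanidine nitrogen

This account rests on a few compounds, and the source may have more. Where it says the series, first, only, none or still open, it means among the compounds named here.

Measured so far:
compound 1, `CCC(/N=C(\NC#N)Nc1ccncc1)C(C)C`, 5 mg/kg
compound 2, `CC(C)C(C)(C)/N=C(\NC#N)Nc1ccncc1`, 20 mg/kg

In a functional assay on the whole organism (blood, strain Wistar-Okamoto) with Rattus norvegicus as the target, with a stated time of 5 days (a higher number here means that more compound is needed for the effect, a lower number that less compound is needed), compound 2 gives the higher of the two numbers, the step of a 4.0-fold higher number from compound 1 to compound 2 (0.60 log units; beyond the scatter) setting it apart from compound 1. Compound 3, `CCC(C)(CC)/N=C(\NC#N)Nc1ccncc1`, is not yet measured. It differs from compound 2 only in the arrangement of the alkyl group: 1-ethyl-1-methylpropyl in place of 1,1,2-trimethylpropyl on a double-bonded nitrogen. Among the measured compounds shown here, the only measured step, a 4.0-fold higher number from compound 1 to compound 2 (0.60 log units; beyond the scatter), concerns a different rearrangement of the same kind of group at the same place, and it was of modest size. The change from compound 2 to compound 3 is smaller in kind, keeping the carbon that binds the nitrogen fully substituted, so no step beyond the scatter is expected in this assay, with the direction uncertain. Compound 3 is therefore estimated at 20 mg/kg, within 7 mg/kg to 60 mg/kg, meaning an expected step of no change at the digits printed from compound 2 to compound 3 (within the scatter).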

Compound 3, minimum effective dose: 0.5 mg/kg
For compound 3 the middle estimate is 40-fold (1.60 log units) above the measured one; measured number outside the range, below it.
By their numbers in this assay, from the lowest: compound 3; then compound 1; then compound 2.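

In this assay, rearranging the same atoms on the double-bonded nitrogen matters far more than the earlier pair suggested: 1-ethyl-1-methylpropyl in place of 1,1,2-trimethylpropyl gives a 40-fold lower number from compound 2 to compound 3 (1.60 log units; beyond the scatter) with no change in the counted features of the group. The same group also gives a 10-fold lower number from compound 1 to compound 3 (1.00 log units; beyond the scatter) when it replaces 1-isopropylpropyl, so compound 3 needs the least compound of the three. A fully substituted carbon on the nitrogen does not by itself settle the dose, since compound 2 and compound 3 both have one yet sit at opposite ends of the series.

As far as these compounds go, whether a longer chain, such as 1,1-diethylpropyl, would lower the number further remains open. Nothing available here explains why this rearrangement has so large an effect.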